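The compounds below may be only part of what the source reports. "The series", "measured", "known", "first", "only" and "open" are said of these compounds alone.

Measured compounds:
Compound 1, `O=C(COc1ccc(C(=O)/C=C/c2cccc(Cl)c2)cc1)N[C@H]1CCOC1=O`: 20900 nM
Compound 2, `CC(C)c1ccc(/C=C/C(=O)c2ccc(OCC(=O)N[C@H]3CCOC3=O)cc2)cc1`: 23400 nM

Both numbers come from a functional assay on MCF7 cells (Homo sapiens) for antiproliferative activity, read by MTT assay, with a stated time of 72 h; a higher number here means a weaker inhibitor, a lower number a stronger inhibitor. Compound 2 and compound 1 are separated only by a 1.1-fold higher number from compound 1 to compound 2 (0.05 log units; within the scatter), a difference that lies within the scatter, so on the numbers shown the two compounds stand level with one another, and compound 2 sits at one end of a pair that cannot be told apart.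

Compound 3, `O=C(COc1ccc(C(=O)/C=C/c2ccc(Br)cc2)cc1)N[C@H]1CCOC1=O`, has not been measured in this assay. It differs from compound 2 by bromo in place of isopropyl on an aromatic carbon. Among the compounds with values here, only one measured step bears on this change: the exchange of 3-chlorophenyl for 4-isopropylphenyl from compound 1 to compound 2 also altered the substituent on that same aryl ring, and it produced a 1.1-fold higher number from compound 1 to compound 2 (0.05 log units; within the scatter), a step within the scatter. Within the data shown here, since the one comparable exchange on this ring left the number essentially unchanged, the step from compound 2 to compound 3 is expected to be no larger than the scatter, a 1.1-fold lower number from compound 2 to compound 3 (0.03 log units; within the scatter). Compound 3 is therefore estimated to give 22000 nM in this assay, with a range from 9000 nM to 55000 nM.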

Compound 3, half-maximal inhibitory concentration: > 64000 nM
Compound 3 ended at the assay's limit; the forecaster's own chance of this, stated with the estimate: 10%; at least 2.9-fold (0.46 log units) between middle value and limit.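

In this assay the reading for compound 3 is a limit of the assay and not a number: the limit of > 64000 nM in this assay, at which 1 of the 3 values shown sits. The substituent on this aryl ring had made no readable difference between 3-chlorophenyl and 4-isopropylphenyl, yet bromo in place of isopropyl gives an at least 2.7-fold higher number from compound 2 to compound 3 (0.43 log units; beyond the scatter), and 4-bromophenyl in place of 3-chlorophenyl gives an at least 3.0-fold higher number from compound 1 to compound 3 (0.48 log units; beyond the scatter). The ring is therefore not indifferent to what it carries: compound 1 and compound 2 stand level, compound 3 is weaker than both, and each step is known only as a minimum size.

The compounds shown leave open whether the loss follows the bromo itself or the 4-bromophenyl arrangement as a whole, a question that 4-chlorophenyl and 3-bromophenyl rings would separate. They also leave open how far compound 3 lies past the limit, and whether an amine or a carboxylic acid on the same aromatic carbon would stay level with compound 2 or fall away like compound 3.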